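Swapping the Aryl Amine: Fluoropyridine to Methylpyrimidine

The source may hold more compounds than are shown below. What is called first, only, known or untested is meant among the compounds shown, and "the series" means these compounds.

This account concerns three measured compounds and a fourth that has not yet been tested. In a functional assay on HEK293 cells for negative allosteric modulation of metabotropic glutamate receptor 5 (Homo sapiens), read by HTRF and inositol phosphate accumulation (a lower number here means a stronger inhibitor, a higher number a weaker inhibitor), compound 3 `CCC[C@@H](NC(=O)c1nccs1)c1cnc(Nc2ccc(F)nc2)c(Cl)c1` gives 12.8 nM, the lowest number of the three. Compound 1 `CCC[C@@H](NC(=O)c1cscn1)c1cnc(Nc2ccc(C)nc2)c(Cl)c1` gives 31.2 nM, and compound 2 `CCC[C@@H](NC(=O)c1nccs1)c1cnc(Nc2cccnc2)c(Cl)c1` gives 71.4 nM. For the measured compounds named here, only one single-point step connects two measured compounds: the change a 5.6-fold lower number from compound 2 to compound 3 (0.75 log units; beyond the scatter), a fluoro in place of hydrogen on an aromatic carbon, which lowered the number modestly but beyond the scatter. Compound 1 differs from compound 3 in more than one place, so its value cannot be assigned to a single change; it shows only that a methyl-bearing aryl amine can sit near the numbers of compound 3.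

The unmeasured compound 4 `CCC[C@@H](NC(=O)c1nccs1)c1cnc(Nc2cnc(C)nc2)c(Cl)c1` arises from compound 3 by 2-methylpyrimidin-5-yl in place of 6-fluoropyridin-3-yl on a nitrogen on an aromatic ring. Going by the values given here, this removes the fluoro whose introduction produced the only measured step and brings in a methyl together with a second ring nitrogen. Among the compounds with values here, no measured step addresses this exchange directly, so the expected size is uncertain. Given the value of compound 1 at 31.2 nM, the number for compound 4 is estimated to move a 2.0-fold higher number from compound 3 to compound 4 (0.29 log units; within the scatter), and compound 4 is expected to give 25 nM, within a range from 8 nM to 80 nM.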

Compound 4, half-maximal inhibitory concentration: 43.9 nM
The estimate for compound 4 lay 1.8-fold (0.24 log units) below the measured number; measured number inside the range.
By their numbers in this assay, from the lowest: compound 3; then compounds 1, 4 and 2 (each within the scatter of the next, the first and the last beyond it).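

At this place on the nitrogen of the aromatic ring, the exchange of 6-fluoropyridin-3-yl for 2-methylpyrimidin-5-yl gave a 3.4-fold higher number from compound 3 to compound 4 (0.54 log units; beyond the scatter) in this assay, so the gain seen with the fluoro did not carry over to this group of equal heavy-atom count. Set against the unsubstituted pyridin-3-yl, the same group gave a 1.6-fold lower number from compound 2 to compound 4 (0.21 log units; within the scatter), which means that in this assay 2-methylpyrimidin-5-yl and pyridin-3-yl cannot be told apart. Among the three groups tested on the shared core with the same amide, only 6-fluoropyridin-3-yl stands apart, with steps beyond the scatter to both of the others, while the methyl and second ring nitrogen together bring no such advantage.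

The compounds shown leave open how the methyl and the second ring nitrogen each contribute, since these arrive together, and how an unsubstituted pyrimidin-5-yl, or a methoxy or nitrile in place of the fluoro, would read in this assay. Nothing available offers an explanation for the differences among these numbers.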